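The source may report more compounds than this note shows. Statements on the series, on what has been measured and on what is new or still open speak of the compounds shown alone.

Of the compounds shown here, three sharing one core have been tested in a functional assay on HT-29 cells (Homo sapiens) for antiproliferative activity, read by sulforhodamine B assay, with a stated time of 72 h; on this read-out lower numbers stand for stronger inhibition and higher numbers for weaker inhibition. Compound 3, `S=C(N/N=C/c1ccc2ccccc2n1)Nc1cccc(Br)c1`, gives 58900 nM in this assay, and it is the only one of the three for which a number rather than a limit is reported. Compound 1, `Fc1ccccc1NC(=S)N/N=C/c1ccc2ccccc2n1`, reaches only the limit > 100000 nM in this assay. Compound 2, `Cc1cccc(NC(=S)N/N=C/c2ccc3ccccc3n2)c1`, likewise stops at the limit > 100000 nM in this assay. Two of the three results thus sit at the limit of > 100000 nM in this assay, at which 2 of the 3 values shown sit, so the step that the two limits leave unreadable from compound 1 to compound 2 cannot be read at all, while the step of an at least 1.6-fold lower number from compound 1 to compound 3 (0.22 log units; that floor lies within the scatter) and the step of an at least 1.6-fold lower number from compound 2 to compound 3 (0.22 log units; that floor lies within the scatter) are each known only as a floor. Those two steps are the ones that bear on the present question, since both exchange the group on the ring carried by the amide-type nitrogen, as does the change now considered.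

Compound 4, `COc1cccc(NC(=S)N/N=C/c2ccc3ccccc3n2)c1`, differs from compound 3 by methoxy in place of bromo on an aromatic carbon. With bromo the only substituent that yielded a number and fluoro and methyl both at the limit, the expectation is that methoxy moves the number back up, and the step of a 1.7-fold higher number from compound 3 to compound 4 (0.23 log units; within the scatter) is the expected size of that move. Compound 4 is therefore estimated at 100000 nM, within 30000 nM to 400000 nM, with a real chance that only a limit is reported.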

Compound 4, half-maximal inhibitory concentration: 82400 nM
The estimate for compound 4 lay 1.2-fold (0.08 log units) above the measured number; the range from low to high includes it.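

In this assay, bromo no longer stands alone in giving a number rather than a limit: a 1.4-fold higher number from compound 3 to compound 4 (0.15 log units; within the scatter). At this place, on an aromatic carbon meta to a large group, bromo and methoxy therefore cannot be told apart, although methyl at the same place, in compound 2, gives only a limit. The comparisons with the other two compounds are only floors, an at least 1.2-fold lower number from compound 2 to compound 4 (0.08 log units; that floor lies within the scatter) and an at least 1.2-fold lower number from compound 1 to compound 4 (0.08 log units; that floor lies within the scatter), so methoxy is not separated from methyl or from the 2-fluorophenyl of compound 1, and this change can be read only weakly because two compounds give no number: the limit of > 100000 nM in this assay, at which 2 of the 4 values shown sit.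

On these data alone, it remains open whether a group of another kind at this place, such as an amine, a carboxylic acid or a longer chain, would give a number clearly apart from those of compound 3 and compound 4. Also open, as far as these compounds go, is whether moving bromo or methoxy elsewhere on that ring would change the number at all.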